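Thiourea in Place of Dithiocarbamate on a Shared Core

This account rests on a few compounds, and the source may have more. Where it says the series, first, only, none or still open, it means among the compounds named here.

Compound 1 `CN1CCN(C(=S)SC(=S)N(C)C)CC1`: in an ADME assay on HeLa cells (Homo sapiens) for cytotoxicity, read by MTT assay, with a stated time of 24 h (on this read-out lower numbers stand for stronger inhibition and higher numbers for weaker inhibition), compound 1 gives 1220000 nM.
Compound 2 `CN(C)C(=S)SC(=S)N1CCN(C(=O)c2ccco2)CC1`: in this assay compound 2 gives 2380000 nM.
Compound 3 `CCCCSC(=S)N1CCN(C(=S)SC(=S)N(C)C)CC1`: in this assay compound 3 gives only a limit, > 5000000 nM.

Compound 3 stands at the limit of this assay (the limit of > 5000000 nM in this assay, at which 1 of the 3 values shown sits), reached by the steps of an at least 4.0-fold higher number from compound 1 to compound 3 (0.61 log units; beyond the scatter) and an at least 2.1-fold higher number from compound 2 to compound 3 (0.32 log units; beyond the scatter). Compound 4 `CN(C)C(=S)SC(=S)N1CCN(C(=S)Nc2ccccc2)CC1` differs from compound 3 by anilino in place of butylsulfanyl on a thiocarbonyl carbon. Among the compounds with values here, no measured step exchanges a group on the thiocarbonyl carbon; the measured steps all alter the group on the ring nitrogen, and both ended at the limit, so they give no direction for this exchange. Since compound 3 is only a limit, its starting point is itself uncertain. Compound 4 is therefore expected near 3000000 nM, ranging from 1000000 nM to 10000000 nM, an estimated step of an at least 1.6-fold lower number from compound 3 to compound 4 (0.22 log units; that floor lies within the scatter).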

Compound 4, half-maximal inhibitory concentration: > 5000000 nM
Compound 4: only a limit was reported (the forecaster's own chance of this, stated with the estimate: 40%); middle value at least 1.6-fold (0.22 log units) from the limit.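

In this assay, within the data shown here, compound 4 gives only a limit, > 5000000 nM and compound 3 is also a limit, so no step between compound 3 and compound 4 can be read: the limit of > 5000000 nM in this assay, at which 2 of the 4 values shown sit. The compounds shown leave open how anilino and butylsulfanyl on the thiocarbonyl carbon compare.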